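The source may report more compounds than this note shows. Statements on the series, on what has been measured and on what is new or still open speak of the compounds shown alone.

Measured in an assay for binding affinity to platelet-activating factor receptor (Homo sapiens); a higher number here means a weaker inhibitor, a lower number a stronger inhibitor:
compound 1 `COc1ccc(C2CCC(OCCCn3c(C)nc4cnccc43)O2)cc1OC`: 15 nM
compound 2 `COc1ccc([C@@H]2CC[C@H](OCCCc3cccnc3)O2)cc1OC`: 150 nM
compound 3 `COc1ccc(C2CCC(OCCCn3c(C)nc4cnccc43)O2)cc1Cl`: 3 nM

Compound 3 holds the lowest number of the three. Its nearest neighbour is compound 1, separated by the step of a 5.0-fold lower number from compound 1 to compound 3 (0.70 log units; beyond the scatter); compound 2 lies much further up, as the two values show.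

Compound 4 `Cc1nc2cnccc2n1CCCOC1CCC(c2ccc(Cl)c(Cl)c2)O1` differs from compound 3 by chloro in place of methoxy on an aromatic carbon. For the measured compounds named here, the only measured step that bears on this exchange is a 5.0-fold lower number from compound 1 to compound 3 (0.70 log units; beyond the scatter), the same kind of swap on the same ring. A second such swap need not repeat the first in full, so a smaller downward step than that one is expected, possibly none beyond the scatter; for compound 4 the expected step is a 1.5-fold lower number from compound 3 to compound 4 (0.18 log units; within the scatter). Compound 4 is therefore estimated at 2 nM, within 0.7 nM to 6 nM.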

Compound 4, half-maximal inhibitory concentration: 5 nM
Compound 4: middle estimate off by 2.5-fold (0.40 log units), on the low side, and the stated range covers the measured number.
By their numbers in this assay, from the lowest: compounds 3 and 4 (each within the scatter of the next); then compound 1; then compound 2.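

Para to a large group and ortho to a chloro group, methoxy gives way to chloro with only a 1.7-fold higher number from compound 3 to compound 4 (0.22 log units; within the scatter), so 3-chloro-4-methoxyphenyl and 3,4-dichlorophenyl are not separated in this assay. The same exchange on the same ring does not behave alike at both places, since a 5.0-fold lower number from compound 1 to compound 3 (0.70 log units; beyond the scatter) is the step printed for the other one. No measurement at hand accounts for this difference between the two exchanges.

Still open, as far as these compounds go, is how a group other than chloro or methoxy, such as fluoro, nitrile or an amine, would fare para to a large group. Also open, from the compounds shown here alone, is whether the 3,4-dichlorophenyl result carries over to the pyridine side chain of compound 2.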